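Moving the hydroxy group on a growth-inhibiting hydrazone

The source may hold more compounds than are shown below. What is called first, only, known or untested is meant among the compounds shown, and "the series" means these compounds.

Measured in a functional assay on NCI/ADR-RES cells (Homo sapiens) for inhibition, read by sulforhodamine B assay, with a stated time of 48 h; a higher number here means a weaker inhibitor of growth, a lower number a stronger inhibitor of growth:
compound 1 `O=C(Cc1csc2nc(-c3ccc(Br)cc3)cn12)N/N=C/c1ccccc1`: 67600 nM
compound 2 `O=C(Cc1csc2nc(-c3ccc(Br)cc3)cn12)N/N=C/c1ccccc1O`: 6760 nM

Of these two values, the lower belongs to compound 2, at 6760 nM, which makes it the stronger inhibitor of growth in this assay. Compound 3 `O=C(Cc1csc2nc(-c3ccc(Br)cc3)cn12)N/N=C/c1ccc(O)cc1` has the same atoms as compound 2, joined differently: 4-hydroxyphenyl in place of 2-hydroxyphenyl on a carbon with a double bond to nitrogen. In words, 4-hydroxyphenyl stands in place of 2-hydroxyphenyl on a carbon with a double bond to nitrogen.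

Within the data shown here, only one measured step bears on this change. Putting hydroxy in place of hydrogen on an aromatic carbon gave a 10-fold lower number from compound 1 to compound 2 (1.00 log units; beyond the scatter), a modest step beyond the scatter. Among the measured compounds shown here, that step shows that the hydroxy group of compound 2 goes with a lower number, but no measured compound shows what 4-hydroxyphenyl does. The expectation is therefore that compound 3 keeps only part of that gain, and the uncertainty is wide. The expected change is a 3.0-fold higher number from compound 2 to compound 3 (0.47 log units; beyond the scatter). The estimated value for compound 3 is 20000 nM, with an expected range of 5000 nM to 70000 nM.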

Compound 3, concentration for total growth inhibition: 61700 nM
Estimate against measurement, compound 3: 3.1-fold (0.49 log units) below; low and high end bracket the measured number.
By their numbers in this assay, from the lowest: compound 2; then compounds 3 and 1 (each within the scatter of the next).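

In this assay, moving the hydroxy group from 2-hydroxyphenyl to 4-hydroxyphenyl gave a 9.1-fold higher number from compound 2 to compound 3 (0.96 log units; beyond the scatter) and removed nearly all of the earlier gain, so that gain cannot be credited to simply having a hydroxy group on this aromatic ring. Adding hydroxy in the 4-hydroxyphenyl arrangement gave a 1.1-fold lower number from compound 1 to compound 3 (0.04 log units; within the scatter), which leaves compound 3 indistinguishable from compound 1, the compound without hydroxy, and makes compound 3 the exception to any rule that hydroxy lowers the number here. Among these three compounds, then, only 2-hydroxyphenyl goes with the stronger inhibition of growth, but nothing available here explains the difference between the two arrangements.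

On these data alone, it remains open whether the hydroxy group of 2-hydroxyphenyl can be replaced, for example by a methoxy group or an amine, while keeping the lower number. It is also unknown whether the same gap between 2-hydroxyphenyl and 4-hydroxyphenyl would appear on a different core, since all three compounds share one.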